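A few compounds are considered here, and "the series" means these few. Any claim that something is new, unique, unknown or untested is made for them only; others in the source may bear on it.

Measured compounds:
- compound 1 `Cc1cc(-c2ccnc(C(F)F)c2)ncc1OC[C@@](C)(N)CC(C)C`: 0.3 nM
- compound 2 `CC(C)C[C@H](N)COc1ccc(-c2ccnc(N)c2)cc1`: 13 nM
- compound 3 `CC(=O)Nc1cc(-c2cc(F)c(OC[C@@H](N)CC(C)C)cc2F)ccn1`: 0.6 nM

All three numbers come from an assay on brain (strain C57BL6) for displacement of a labelled ligand from AP2-associated protein kinase 1 (Mus musculus), read by scintillation counting, with a stated time of 1 h; a higher number here means a weaker inhibitor, a lower number a stronger inhibitor. Compound 2 stands at the highest number of the three: compound 3 sits far lower, and compound 1 lower still, both gaps well beyond the usual scatter of repeated measurements. Compound 2 is therefore the weakest of the measured set.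

Compound 4 `CC(=O)Nc1cc(-c2ccc(OC[C@@H](N)CC(C)C)cc2)ccn1` has not yet been measured in this assay. Against compound 2 the change is acetyl in place of hydrogen on a nitrogen on an aromatic ring. Going by the values given here, no measured pair differs in only this one place, so the change has no directly measured step behind it. Compound 3 does carry the acetamido group and gives a far lower number than compound 2, but compound 3 also differs from compound 2 elsewhere, so its value only points the way.

On that basis the step from compound 2 to compound 4 in this assay is expected to run toward a lower number, and by more than the scatter. Compound 4 is estimated at 1.5 nM, in a range of 0.4 nM to 5 nM. The expected step is an 8.7-fold lower number from compound 2 to compound 4 (0.94 log units; beyond the scatter).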

Compound 4, inhibition constant: 0.9 nM
For compound 4 the middle estimate is 1.7-fold (0.22 log units) above the measured one; measured number inside the range.
By their numbers in this assay, from the lowest: compounds 1, 3 and 4 (each within the scatter of the next, the first and the last beyond it); then compound 2.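

Acetyl in place of hydrogen on a nitrogen on an aromatic ring gives a 14-fold lower number from compound 2 to compound 4 (1.16 log units; beyond the scatter) in this assay, and this is the first measured step in the series that isolates the amino to acetamido change. Going by these compounds alone, until now, the acetamido group was seen only in compound 3, which also differs from compound 2 elsewhere; the large step now ties a lower number to this single change on the shared core. A free amino group is therefore not needed at this position for a low number in this assay, although nothing available explains the size of the step.

From the compounds shown here alone, it remains open whether the lower number depends specifically on the acetyl group or would also follow from another group on the same nitrogen, such as methyl, propanoyl or methanesulfonyl. A single pair also leaves open whether the step carries over to a different core, such as that of compound 3.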